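Returning from 4-chlorophenyl to a 3-substituted aryl

The source may hold more compounds than are shown below. What is called first, only, known or untested is meant among the compounds shown, and "the series" means these compounds.

Measured so far in a functional assay on HEK293 cells for positive allosteric modulation of metabotropic glutamate receptor 5 (Homo sapiens), read by FLIPR and calcium flux; a lower number here means that less compound is needed, a higher number that more compound is needed for the effect:
compound 1 `Cc1cccc(C#Cc2ccc3c(n2)CCN(C2CCCC2)C3=O)c1` gives 7.5 nM;
compound 2 `O=C1c2ccc(C#Cc3cccc(Cl)c3)nc2CCN1C1CCCC1` gives 33 nM;
compound 3 `O=C1c2ccc(C#Cc3ccc(Cl)cc3)nc2CCN1C1CCCC1` gives 979 nM.

Compound 3 stands highest of the three, needing the most compound. Compound 4 `COc1cccc(C#Cc2ccc3c(n2)CCN(C2CCCC2)C3=O)c1` differs from it by 3-methoxyphenyl in place of 4-chlorophenyl on a triple-bonded carbon. Going by the values given here, two steps bear on this. The 4-chlorophenyl of compound 3 gave a 30-fold higher number from compound 2 to compound 3 (1.47 log units; beyond the scatter), while swapping the 3-methylphenyl for 3-chlorophenyl gave a 4.4-fold higher number from compound 1 to compound 2 (0.64 log units; beyond the scatter). Compound 4 carries its substituent as 3-methoxyphenyl, in the manner of compound 1 and compound 2 rather than compound 3, so a large drop is expected, a 49-fold lower number from compound 3 to compound 4 (1.69 log units; beyond the scatter). Compound 4 is estimated at 20 nM, with a range from 5 nM to 80 nM.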

Compound 4, half-maximal effective concentration: 462 nM
Compound 4: the middle estimate sits 23-fold (1.36 log units) below what was measured, outside the stated range (above it).
By their numbers in this assay, from the lowest: compound 1; then compound 2; then compound 4; then compound 3.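

In this assay the 3-methoxyphenyl group does not match its 3-substituted relatives: methoxy in place of chloro gives a 14-fold higher number from compound 2 to compound 4 (1.15 log units; beyond the scatter) and methoxy in place of methyl gives a 62-fold higher number from compound 1 to compound 4 (1.79 log units; beyond the scatter). Set against 4-chlorophenyl, the change to 3-methoxyphenyl gives only a 2.1-fold lower number from compound 3 to compound 4 (0.33 log units; beyond the scatter), so among these compounds the identity of the group counts as well as where it sits. Nothing available explains this difference between methyl, chloro and methoxy. As far as these compounds go, whether fluoro, a nitrile or an amine in that same place would behave like methyl or like methoxy stays open.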